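Thioester in place of the chain acid

A few compounds are considered here, and "the series" means these few. Any claim that something is new, unique, unknown or untested is made for them only; others in the source may bear on it.

The series shares the core of compound 1 `O=Cc1ccc(-c2cnc(C(=O)CCCCCCc3ccccc3)o2)nc1`, which in an assay for inhibition of Fatty-acid amide hydrolase 1 (Rattus norvegicus), using a Dixon plot (a higher number here means a weaker inhibitor, a lower number a stronger inhibitor), gives 2.2 nM. Among the measured compounds shown here, compound 2 `O=C(O)CCCCc1cnc(C(=O)CCCCCCc2ccccc2)o1` gives 23.8 nM, the higher of the two numbers, and the only measured step is an 11-fold higher number from compound 1 to compound 2 (1.03 log units; beyond the scatter). Compound 3 `CSC(=O)CCCCc1cnc(C(=O)CCCCCCc2ccccc2)o1` carries methylsulfanyl in place of hydroxy on a carbonyl carbon. For the measured compounds named here, that step exchanged a different part of the molecule, so it bears on the present change only loosely, and no measured step touches the carbonyl substituent. Relative to compound 2, compound 3 is expected to shift only modestly in this assay, a 2.4-fold lower number from compound 2 to compound 3 (0.38 log units; beyond the scatter). The estimate for compound 3 is 10 nM, in the range 3 nM to 40 nM.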

Compound 3, inhibition constant: 1.8 nM
Beside the measured number, compound 3's estimate is 5.6-fold (0.74 log units) above it, and the stated range ends above it.
By their numbers in this assay, from the lowest: compounds 3 and 1 (each within the scatter of the next); then compound 2.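

The carbonyl carbon at the end of the chain responds strongly to its substituent: methylsulfanyl in place of hydroxy gives, in this assay, a 13-fold lower number from compound 2 to compound 3 (1.12 log units; beyond the scatter). The ring-free chain group of compound 3 also matches the ring-bearing group of compound 1, with a 1.2-fold lower number from compound 1 to compound 3 (0.09 log units; within the scatter). Nothing available accounts for the size of the step from hydroxy to methylsulfanyl.

Going by these compounds, whether the sulfur or the added methyl carries the change stays open; a methyl ester or a primary amide on the same carbonyl carbon would separate the two. On these data alone, the effect of a longer chain carrying the thioester is also open.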